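This account rests on a few compounds, and the source may have more. Where it says the series, first, only, none or still open, it means among the compounds named here.

Values in a physicochemical assay for solubility, read by HPLC, in phosphate buffer, at pH 6.5; on this read-out higher numbers stand for higher solubility and lower numbers for lower solubility:
- compound 1 `COC(=O)C1=C(CN2CCOCC2=O)NC(c2nccs2)=NC1(C)c1ccc(F)cc1` gives 440 ug/mL
- compound 2 `COC(=O)C1=C(CN2CCC(C(F)(F)F)C2)NC(c2nccs2)=NC1(C)c1ccc(F)cc1` gives 13 ug/mL
- compound 3 `COC(=O)C1=C(CN2CCCS2(=O)=O)NC(c2nccs2)=NC1(C)c1ccc(F)cc1` gives 125 ug/mL

Of the three numbers, the middle one belongs to compound 3 with 125 ug/mL, below compound 1 and above compound 2.

The next step leads to compound 4 `COC(=O)C1=C(CN(C)C2(C(=O)O)CC2)NC(c2nccs2)=NC1(C)c1ccc(F)cc1` and is a group of 8 heavy atoms (5 carbon, 1 nitrogen, 2 oxygen; one three-membered non-aromatic ring of carbon only) in place of a group of 7 heavy atoms (3 carbon, 1 nitrogen, 2 oxygen, 1 sulfur; one five-membered non-aromatic ring with 2 hetero atoms), on a saturated chain carbon bound to a double-bonded ring carbon. The group that enters has 1 hydrogen-bond donor, and the group that leaves has 0 hydrogen-bond donors. Both have no net charge.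

All three measured steps changed this same place, and all lie beyond the scatter. The large one is a 34-fold lower number from compound 1 to compound 2 (1.53 log units; beyond the scatter). The modest ones are a 3.5-fold lower number from compound 1 to compound 3 (0.55 log units; beyond the scatter) and a 9.6-fold higher number from compound 2 to compound 3 (0.98 log units; beyond the scatter). Among these three compounds, the groups with 2 oxygen, in compound 1 and compound 3, give higher numbers than the group with 3 fluorine in compound 2, and none of the three goes against this. Within the data shown here, the group entering in compound 4 also has 2 oxygen, but no measured compound has a hydrogen-bond donor in this group, so the direction is only a tentative call.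

A modest upward move is expected in this assay, and the expected step is a 3.6-fold higher number from compound 3 to compound 4 (0.56 log units; beyond the scatter). For compound 4 the estimate is 450 ug/mL, with an expected range of 120 ug/mL to 1500 ug/mL.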

Compound 4, solubility: > 510 ug/mL
Compound 4 ended at the assay's limit; the forecaster's own chance of this, stated with the estimate: 15%; at least 1.1-fold (0.05 log units) between middle value and limit.
By their numbers in this assay, from the lowest: compound 2; then compound 3; then compound 1. At a limit, above all of these: compound 4.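

In this assay, compound 4 brings the first hydrogen-bond donor to the group on a saturated chain carbon bound to a double-bonded ring carbon, and the number does not fall: the steps read an at least 4.0-fold higher number from compound 3 to compound 4 (0.61 log units; beyond the scatter), an at least 39-fold higher number from compound 2 to compound 4 (1.59 log units; beyond the scatter) and an at least 1.1-fold higher number from compound 1 to compound 4 (0.06 log units; that floor lies within the scatter). Among these compounds, the earlier split also still stands, with all three groups with 2 oxygen, in compound 1, compound 3 and compound 4, giving higher numbers than the group with 3 fluorine in compound 2, and no compound going against it. Compound 4 sits at a limit, which is not a number, and the floor of the last of these steps lies within the scatter, so no order between compound 4 and compound 1 can be stated: the limit of > 510 ug/mL in this assay, at which 1 of the 4 values shown sits.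

Still open, going by these compounds, is how far compound 4 lies past its limit, and whether the donor, the three-membered ring of carbon only or the whole entering group goes with the step, since these differ together from compound 3. A methyl ester in place of the carboxylic acid, or an open chain with a hydroxyl group in place of the three-membered ring, at this same place would separate these parts.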